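The source may report more compounds than this note shows. Statements on the series, on what has been measured and on what is new or still open speak of the compounds shown alone.

Compound 1 `CO[C@H]1CC[C@H](NC(=O)c2n[nH]cc2NC(=O)c2cnc3ccccn23)CC1`: 5900 nM
Compound 2 `COc1cccc(OC)c1C(=O)Nc1c[nH]nc1C(=O)NCc1ncccc1C`: > 50000 nM
Compound 3 `CO[C@H]1CC[C@H](NC(=O)c2n[nH]cc2NC(=O)c2ccccc2)CC1`: 800 nM

Within the data shown here, in an ADME assay on MRC5 cells (Homo sapiens) for inhibition, with a stated time of 72 h (on this read-out lower numbers stand for an effect already at smaller amounts and higher numbers for an effect only at larger amounts of compound), compound 3 gives 800 nM and compound 1 gives 5900 nM; the only measured step is a 7.4-fold lower number from compound 1 to compound 3 (0.87 log units; beyond the scatter), and it sits on a carbonyl carbon. For compound 2 this assay reports no number but a limit, (the limit of > 50000 nM in this assay, at which 1 of the 3 values shown sits). Compound 4 `COc1cccc(OC)c1C(=O)Nc1c[nH]nc1C(=O)NCC1CCCCC1` differs from compound 2 in one place: cyclohexyl in place of 3-methylpyridin-2-yl on a saturated chain carbon bound to an amide-type nitrogen. Among the measured compounds shown here, no measured step touches this place, so the measured step gives no guide, and the only anchor is the limit of compound 2. Compound 4 is therefore expected to stay near that limit, with a step that the limit leaves unreadable from compound 2 to compound 4. The estimate for compound 4 is 60000 nM, in a range from 15000 nM to 200000 nM.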

Compound 4, half-maximal effective concentration: > 50000 nM
Compound 4: no number, only a limit (the forecaster's own chance of this, stated with the estimate: 70%); the middle value does not contradict the limit.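

Compound 2 and compound 4 each give only a limit, not a number, in this assay, so no step can be read between them: the limit of > 50000 nM in this assay, at which 2 of the 4 values shown sit.

The compounds shown leave open whether cyclohexyl in place of 3-methylpyridin-2-yl changes the read-out at all.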